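This account rests on a few compounds, and the source may have more. Where it says the series, first, only, none or still open, it means among the compounds named here.

In a functional assay on the whole organism with Rattus norvegicus as the target (on this read-out lower numbers stand for an effect already at smaller amounts and higher numbers for an effect only at larger amounts of compound), three compounds sharing one core have been measured. Compound 1 `CCOC(=O)C(=O)Nc1nc(-c2ccc(O)cc2)cs1` gives about 15 mg/kg, compound 2 `CCOC(=O)C(=O)Nc1nc(-c2ccc(OC)cc2)cs1` gives about 10 mg/kg, and compound 3 `CCOC(=O)C(=O)Nc1nc(-c2ccc(NC(=O)C(F)(F)F)cc2)cs1` gives about 1 mg/kg. Compound 3 therefore holds the lowest number of the three, and its steps to both others lie beyond the scatter. Methyl in place of hydrogen on the oxygen makes no clear difference, with a 1.5-fold lower number from compound 1 to compound 2 (0.18 log units; within the scatter). The ((trifluoromethyl)carbonyl)amino group, by contrast, gives a 15-fold lower number from compound 1 to compound 3 (1.18 log units; beyond the scatter) in place of hydroxy and a 10-fold lower number from compound 2 to compound 3 (1.00 log units; beyond the scatter) in place of methoxy.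

The next compound is compound 4 `CCOC(=O)C(=O)Nc1nc(-c2ccc(C(=O)OCC)cc2)cs1`, which carries ethoxycarbonyl in place of ((trifluoromethyl)carbonyl)amino on an aromatic carbon. Going by the values given here, no measured step involves ethoxycarbonyl, so the evidence is indirect. Only the two steps into compound 3 bear on the change, and both run towards a lower number when ((trifluoromethyl)carbonyl)amino enters. Its loss should thus give back part of a 10-fold lower number from compound 2 to compound 3 (1.00 log units; beyond the scatter), though perhaps not all of it, since the entering group resembles neither hydroxy nor methoxy. In this assay, the expected change is a 4.0-fold higher number from compound 3 to compound 4 (0.60 log units; beyond the scatter), an estimated rise in the number that is moderate in size and uncertain. For compound 4 the estimate is 4 mg/kg, with an expected range from 1.5 mg/kg to 12 mg/kg.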

Compound 4, dose for half-maximal effect: > 10 mg/kg
Compound 4 gave a limit, no number; the forecaster's own chance of this, stated with the estimate: 3%; middle value at least 2.5-fold (0.39 log units) away from the limit.
By their numbers in this assay, from the lowest: compound 3; then compounds 2 and 1 (each within the scatter of the next).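

Compound 4 gives only a limit and not a number in this assay: the limit of > 10 mg/kg in this assay, at which 1 of the 4 values shown sits. Even so, the limit is informative at this position, on an aromatic carbon para to a large group: ethoxycarbonyl does not hold the low number reached with ((trifluoromethyl)carbonyl)amino, with an at least 10-fold higher number from compound 3 to compound 4 (1.00 log units; beyond the scatter), so a second group in this place now fails to match compound 3, and not only hydroxy and methoxy. Ethoxycarbonyl also brings no gain over methoxy, with a number no lower from compound 2 to compound 4 (the limit leaves the size open), while the comparison with compound 1 cannot be read, so among the four compounds the low number remains confined to compound 3.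

On these data alone, it remains open which part of ((trifluoromethyl)carbonyl)amino carries the low number, the amide hydrogen or the trifluoromethyl, and a plain acetylamino group or a free amine in this place would separate the two. As far as these compounds go, it also remains open whether a carboxylic acid in place of ethoxycarbonyl would move the number in either direction.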